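The compounds below may be only part of what the source reports. "The series", "measured", "known", "first", "only" and "open" are said of these compounds alone.

Compound 1: `O=C1N=C(C2C(=O)c3ccccc3C2=O)CC(c2ccccc2[N+](=O)[O-])N1` gives 11%
Compound 2: `O=C1N=C(C2C(=O)c3ccccc3C2=O)CC(c2ccccc2)N1` gives 20%
Compound 3: `O=C1N=C(C2C(=O)c3ccccc3C2=O)CC(c2cccc([N+](=O)[O-])c2)N1` gives 27%

Of the compounds shown here, three sharing one core have been tested in a functional assay on the whole organism for inhibition, with Rattus norvegicus as the target, read by paw edema, with stated times of 30 min and 1 h, at a dose of 10 mg/kg by the oral route; a lower number here means less inhibition, a higher number more inhibition at the dose given (going by the name of the read-out). Compound 3 stands beyond the scatter above compound 1, as the step of a number 16 percentage points higher from compound 1 to compound 3 (beyond the scatter) shows, whereas its gap to compound 2, the step of a number 7 percentage points higher from compound 2 to compound 3 (within the scatter), lies within the scatter. Compound 4, `O=C1N=C(C2C(=O)c3ccccc3C2=O)CC(c2ccc([N+](=O)[O-])cc2)N1`, is the next compound for this assay. It differs from compound 3 in one place: 4-nitrophenyl in place of 3-nitrophenyl on a saturated ring carbon.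

Two kinds of measured step bear on this change. Moving the nitro from one ring position to another on the phenyl ring, in a number 16 percentage points higher from compound 1 to compound 3 (beyond the scatter), gave a modest rise. Removing the nitro, in a number 9 percentage points higher from compound 1 to compound 2 (within the scatter), and adding it, in a number 7 percentage points higher from compound 2 to compound 3 (within the scatter), both stayed within the scatter. Taken together, where the nitro sits on the phenyl ring has shifted this assay by little, and nothing among these three compounds shows which way a third placement would move. The step expected here, a number 2 percentage points lower from compound 3 to compound 4 (within the scatter), is therefore small and within the scatter, in no particular direction. Compound 4 is estimated at 25%, with a range from 12% to 38%.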

Compound 4, a percentage reported as inhibition, in the whole organism at one dose (the size of the read-out at that dose, not a potency): 16%
For compound 4 the middle estimate is 9 percentage points above the measured one; the range from low to high includes it.
By their numbers in this assay, from the lowest: compounds 1, 4, 2 and 3 (each within the scatter of the next, the first and the last beyond it).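

In this assay, the placement of the nitro on the phenyl ring now shows a step between two placements not compared before: 4-nitrophenyl in place of 3-nitrophenyl gave a number 11 percentage points lower from compound 3 to compound 4 (beyond the scatter), so compound 3 stands clear of both other nitro compounds, and the gap between placements is no longer tied to the 2-nitrophenyl compound alone. The other two comparisons do not separate: nitro in place of hydrogen gave a number 4 percentage points lower from compound 2 to compound 4 (within the scatter), and 4-nitrophenyl in place of 2-nitrophenyl gave a number 5 percentage points higher from compound 1 to compound 4 (within the scatter), so nitro against hydrogen stays within the scatter at all three placements, compounds 1, 3 and 4 each set against compound 2. Nothing available here accounts for the difference between the 3-nitrophenyl and 4-nitrophenyl placements.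

The compounds shown leave open whether this step belongs to the nitro itself or would recur with an amine or a carboxylic acid at the same places on the phenyl ring. They also leave open whether the order seen at this one oral dose would hold at other doses, since these readings give the size of the effect and not a potency.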